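From bromo to hydroxy on the shared core

A few compounds are considered here, and "the series" means these few. Any claim that something is new, unique, unknown or untested is made for them only; others in the source may bear on it.

In a functional assay on B16-F10 cells (Mus musculus) for cytotoxicity (on this read-out higher numbers stand for weaker inhibition and lower numbers for stronger inhibition), compound 1 (`O=c1oc2ccccc2c2nc3c(ccc4cc[nH]c43)c(-c3cccc(Br)c3)c12`) gives 70700 nM, compound 2 (`O=c1oc2ccccc2c2nc3c(ccc4cc[nH]c43)c(-c3ccc(Br)cc3)c12`) gives 70700 nM, and the much smaller compound 3 (`O=c1cc(O)c2cc(F)ccc2o1`) gives 70700 nM, so compound 2 stands level with both. Compound 4 (`O=c1oc2ccccc2c2nc3c(ccc4cc[nH]c43)c(-c3ccc(O)cc3)c12`) carries hydroxy in place of bromo on an aromatic carbon of compound 2: hydroxy in place of bromo on an aromatic carbon. Among the measured compounds shown here, only one measured step bears on this change. On these data alone, that step, no change at the digits printed from compound 1 to compound 2 (within the scatter), moves the bromine but never replaces it, so the hydroxy group itself remains untested. No shift beyond the scatter is therefore expected in this assay. The estimated 1.2-fold lower number from compound 2 to compound 4 (0.07 log units; within the scatter) is small. Compound 4 is expected at about 60000 nM, within a range of 20000 nM to 100000 nM.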

Compound 4, half-maximal inhibitory concentration: 70700 nM
Beside the measured number, compound 4's estimate is 1.2-fold (0.07 log units) below it, and the stated range covers the measured number.
By their numbers in this assay, from the lowest: compounds 1, 2, 3 and 4 (each within the scatter of the next).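

Replacing the atom, not merely moving it, also leaves this assay unmoved: the exchange of bromo for hydroxy on this aromatic carbon, para to a large group, gives no change at the digits printed from compound 2 to compound 4 (within the scatter). Changing the group and its place together, 4-hydroxyphenyl in place of 3-bromophenyl, likewise gives no change at the digits printed from compound 1 to compound 4 (within the scatter). Nothing available offers an account of this flat result.

On these data alone, whether an amine or a carboxylic acid on this aromatic carbon would shift the number remains open. So does whether a longer chain there would do so.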